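Sulfonyl substituent series: the step from compound 3 to compound 4

The source may report more compounds than this note shows. Statements on the series, on what has been measured and on what is new or still open speak of the compounds shown alone.

Measured so far:
compound 1 `CC1(C)C=C(n2ccccc2=O)c2cc(S(N)(=O)=O)ccc2O1` gives 92.1%
compound 2 `CNS(=O)(=O)c1ccc2c(c1)C(n1ccccc1=O)=CC(C)(C)O2` gives 83%
compound 3 `CC1(C)C=C(n2ccccc2=O)c2cc(S(=O)(=O)N3CCOCC3)ccc2O1` gives 85.1%

All three numbers come from a functional assay on the whole organism (trachea) with Rattus norvegicus as the target; on this read-out lower numbers stand for smaller maximal responses and higher numbers for larger maximal responses. Compound 3 stands second highest of the three, but the gaps around it are small: a number 2.1 percentage points higher from compound 2 to compound 3 (within the scatter) and a number 7 percentage points lower from compound 1 to compound 3 (within the scatter) are both within the scatter, so nothing separates the three compounds on this read-out.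

Compound 4 `CC1(C)C=C(n2ccccc2=O)c2cc(S(=O)(=O)NC(=O)Nc3ccccc3)ccc2O1` differs from compound 3 only at the sulfonyl sulfur: (phenylcarbamoyl)amino in place of morpholin-4-yl on a sulfonyl sulfur. For the measured compounds named here, the steps that bear on this change are the two that also replaced the group on this sulfur, a number 7 percentage points lower from compound 1 to compound 3 (within the scatter) and a number 2.1 percentage points higher from compound 2 to compound 3 (within the scatter); together with a number 9.1 percentage points lower from compound 1 to compound 2 (within the scatter) they show that amino, methylamino and morpholin-4-yl all land within the scatter of one another. The entering (phenylcarbamoyl)amino is larger than any group tried so far, so the expectation rests on a short extrapolation from three nearly equal numbers.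

For compound 4 no step beyond the scatter is expected, only a small downward drift, a number 5.1 percentage points lower from compound 3 to compound 4 (within the scatter), with a widened range for the untried group. Compound 4 is therefore estimated at 80% in this assay, between 58% and 96%.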

Compound 4, largest response reached (Emax), in percent of the reference or control that the assay uses: 99.5%
Estimate against measurement, compound 4: 19.5 percentage points below; the whole stated range lies below it.
By their numbers in this assay, from the lowest: compounds 2, 3, 1 and 4 (each within the scatter of the next, the first and the last beyond it).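

In this assay, for the compounds shown here, the group on the sulfonyl sulfur can move the number beyond the scatter after all: (phenylcarbamoyl)amino in place of morpholin-4-yl gives a number 14.4 percentage points higher from compound 3 to compound 4 (beyond the scatter) and phenylcarbamoyl in place of methyl on the sulfonamide nitrogen gives a number 16.5 percentage points higher from compound 2 to compound 4 (beyond the scatter), both modest, whereas no step among the amino, methylamino and morpholin-4-yl compounds left the scatter. The change is not separated from the unsubstituted sulfonamide, since phenylcarbamoyl in place of hydrogen on the sulfonamide nitrogen gives a number 7.4 percentage points higher from compound 1 to compound 4 (within the scatter), so the new group parts compound 4 from compound 2 and compound 3 but not from compound 1. Nothing among the data available speaks to the origin of these steps.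

Open, as far as these compounds go, is which part of the entering group carries the steps, a question that an acetyl on the sulfonamide nitrogen or a (methylcarbamoyl)amino group on the sulfonyl sulfur would address by removing the phenyl ring. Also open, from the compounds shown here alone, is whether a chlorine or methoxy group on that phenyl ring, or a benzyl group in its place, would keep the number where compound 4 stands.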